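Toward Compound 4 from a Limit-Bound Starting Point

The source may report more compounds than this note shows. Statements on the series, on what has been measured and on what is new or still open speak of the compounds shown alone.

Compound 1 `Cc1c(F)c(Oc2cccc(N)c2)nc(Oc2cccc(C(=N)N)c2)c1F` stands in an assay on isolated protein for inhibition of serine protease 1 (Bos taurus) (a lower number here means a stronger inhibitor, a higher number a weaker inhibitor), only at a limit: compound 1 gives > 5000 nM, which is a limit of the assay and not a number. Compound 2 `Cc1c(F)c(Oc2cccc(C(=N)N)c2)nc(Oc2cccc(C(=O)N3CCCC3)c2)c1F` gives 2800 nM. Compound 3 `Cc1c(F)c(Oc2cccc(C(=N)N)c2)nc(Oc2cccc(C(=O)N3CCOCC3)c2)c1F` likewise sits at a limit, giving > 5000 nM. The change to compound 4 `Cc1c(F)c(Oc2cccc(C(=N)N)c2)nc(Oc2ccc(Cl)c(N(C)C)c2)c1F` is 4-chloro-3-(dimethylamino)phenyl in place of 3-aminophenyl on an oxygen on an aromatic ring. The two measured steps alter the same 3-aminophenyl group but in a different way: an at least 1.7-fold lower number from compound 1 to compound 2 (0.25 log units; that floor lies within the scatter), while a step that the two limits leave unreadable from compound 1 to compound 3; both start from the limit of > 5000 nM in this assay, at which 2 of the 3 values shown sit. Neither carries a readable direction over to the new group, so no move beyond the scatter is expected, and the estimate for compound 4 is 4000 nM, within 1000 nM to 10000 nM, which means an expected at least 1.2-fold lower number from compound 1 to compound 4 (0.09 log units; that floor lies within the scatter).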

Compound 4, inhibition constant: 1000 nM
Estimate against measurement, compound 4: 4.0-fold (0.60 log units) above, within the range that was stated.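

Among these compounds, at this position, on an oxygen on an aromatic ring, putting 4-chloro-3-(dimethylamino)phenyl in place of 3-aminophenyl gives an at least 5.0-fold lower number from compound 1 to compound 4 (0.69 log units; beyond the scatter) in this assay and is the first step from compound 1 to read beyond the scatter. The other steps from compound 1 show no such move. This size is only a floor because compound 1 stands at a limit: the limit of > 5000 nM in this assay, at which 2 of the 4 values shown sit.

The chlorine and the dimethylamino group enter together, so their shares stay unseparated. From the compounds shown here alone, whether 4-chloro-3-aminophenyl or 3-(dimethylamino)phenyl alone would carry the change remains open.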